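Phenethyl in Place of Pyridinyl on an Inactive Amide

A few compounds are considered here, and "the series" means these few. Any claim that something is new, unique, unknown or untested is made for them only; others in the source may bear on it.

Compound 1 `CCn1nc(C)cc1C(=O)Nc1nc2cc(C(N)=O)cc(OC)c2n1CCCNC(=O)OCc1ccccc1`, compound 2 `CCCn1c(NC(=O)c2cc(C)nn2CC)nc2cccc(OC)c21` and compound 3 `CCCn1c(NC(=O)c2ccccn2)nc2cc(C(N)=O)cc(OC)c21` all carry an amide on a shared core, and all were tested in an assay for activation of interferon regulatory factor 3 (Homo sapiens), read by a luciferase reporter, with a stated time of 20 h; a lower number here means that less compound is needed, a higher number that more compound is needed for the effect. For compound 1 the result is only a limit of the assay, > 100000 nM. For compound 2 the result is likewise a limit, > 100000 nM. Compound 3 also gives only a limit, > 100000 nM. So compound 3 stands at the limit of > 100000 nM in this assay, at which 3 of the 3 values shown sit, with no number of its own to compare. Compound 4 `CCCn1c(NC(=O)CCc2ccccc2)nc2cc(C(N)=O)cc(OC)c21` differs from compound 3 in one place: phenethyl in place of pyridin-2-yl on a carbonyl carbon. No measured step joins two of these compounds, so nothing here tells how large such a change might be. With every neighbour at the limit, compound 4 is expected to show no gain beyond the scatter, a step of a number no higher from compound 3 to compound 4 (the limit leaves the size open). The estimate for compound 4 is 100000 nM, within 30000 nM to 300000 nM.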

Compound 4, half-maximal effective concentration: > 100000 nM
Compound 4: no number, only a limit (the forecaster's own chance of this, stated with the estimate: 80%); the middle value lies on the limit itself.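

Going by these compounds alone, compound 3 and compound 4 both give only a limit, so no step between them can be read: the limit of > 100000 nM in this assay, at which 4 of the 4 values shown sit. The compounds shown leave open which change on the shared core, if any, would give a measurable effect.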